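The compounds below may be only part of what the source reports. "The series", "measured", "known", "first", "only" and "open" are said of these compounds alone.

Among the measured compounds shown here, three related compounds have entries in a functional assay on NCI-H1993 cells (Homo sapiens) for inhibition, read by CCK-8 assay, with a stated time of 72 h (a lower number here means a stronger inhibitor, a higher number a weaker inhibitor), but only one has a number. For compound 1 `CCC(c1cc2cccnc2cc1F)n1cnc2ncc(-c3cnn(C)c3)nc21` the entry reads "not determined" (no result reported), and for compound 3 `CCC(c1ccc2ncccc2c1F)n1cnc2ncc(-c3cnn(CCO)c3)nc21` it reads "not determined" (no result reported). Compound 2 `Cc1c(C(C)n2cnc3ncc(-c4cn[nH]c4)nc32)ccc2ncccc12` gives 599 nM, so it stands alone on the numbers and cannot yet be ranked against anything.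

Compound 4 `Cc1c(C(C)n2cnc3ncc(-c4cnc5ccccc5c4)nc32)ccc2ncccc12` keeps the rest of compound 2 and changes one group, with quinolin-3-yl in place of 1H-pyrazol-4-yl on an aromatic carbon. For the measured compounds named here, no measured pair here differs in just one place, so nothing shows directly what such a swap does. Going by the values given here, the only anchor is compound 2 at 599 nM, and the entering group is the larger of the two, so the expectation leans cautiously toward weaker inhibition. The expected change is a 2.5-fold higher number from compound 2 to compound 4 (0.40 log units; beyond the scatter), and it is held with wide uncertainty. For compound 4 the estimated value is 1500 nM, with an expected range from 350 nM to 6000 nM.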

Compound 4, half-maximal inhibitory concentration: 450 nM
Compound 4: the middle estimate sits 3.3-fold (0.52 log units) above what was measured; low and high end bracket the measured number.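

In this assay, this pair gives the first comparison across a single change, and the number barely moves: putting quinolin-3-yl in place of 1H-pyrazol-4-yl gives a 1.3-fold lower number from compound 2 to compound 4 (0.12 log units; within the scatter) and stays within the usual scatter of repeated measurements. So this aromatic carbon can carry a group with more heavy atoms, and a second ring, without a difference that can be read in this assay. The hydrogen-bond donor of 1H-pyrazol-4-yl is also gone in quinolin-3-yl, yet the two compounds still cannot be told apart, and nothing available explains why they match.

The compounds shown leave open how a plain phenyl ring, or a ring carrying an amine such as piperazine, would behave at this position. They also leave open whether the same tolerance holds for other substituents on the rest of the molecule.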